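The source may report more compounds than this note shows. Statements on the series, on what has been measured and on what is new or still open speak of the compounds shown alone.

Compound 1, with the structure `O=C(N/N=C/c1cc(I)c(O)c(I)c1)c1ccc(Br)cc1`, and compound 2, with the structure `O=C(N/N=C/c1cc(I)c(O)c(I)c1)c1ccc(I)cc1`, share one core and differ only in the change (iodo in place of bromo on an aromatic carbon). Compound 3, with the structure `O=C(NNC(=O)c1cc(I)cc(I)c1O)c1ccc(Br)cc1`, and the not yet measured compound 4, with the structure `O=C(NNC(=O)c1cc(I)cc(I)c1O)c1ccc(I)cc1`, share a second core, and the difference between the two cores is not broken down here. Between compound 3 and compound 4 the change is iodo in place of bromo on an aromatic carbon, the same change as between compound 1 and compound 2.

In a functional assay on HepG2 cells (Homo sapiens) for cytotoxicity, with a stated time of 24 h (on this read-out lower numbers stand for stronger inhibition and higher numbers for weaker inhibition), compound 1 gives only a limit of the assay, > 50000 nM. In this assay compound 2 likewise gives only a limit, > 50000 nM. The step from compound 1 to compound 2 is therefore a step that the two limits leave unreadable from compound 1 to compound 2, because the limit of > 50000 nM in this assay, at which 2 of the 3 values shown sit, is where both of these values sit. In this assay compound 3 gives 62800 nM, the only number among the three measurements shown.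

For compound 4 the expectation rests on compound 3, whose value 62800 nM is the only number shown, and on the unreadable step that the two limits leave unreadable from compound 1 to compound 2, which gives no sign that the change shifts the read-out. The step from compound 3 to compound 4 in this assay is expected to be a 1.0-fold lower number from compound 3 to compound 4 (0.02 log units; within the scatter), within the usual scatter. Compound 4 in this assay is estimated at 60000 nM, with a likely span from 30000 nM to 150000 nM.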

Compound 4, half-maximal inhibitory concentration: 25100 nM
Estimate against measurement, compound 4: 2.4-fold (0.38 log units) above, and the stated range ends above it.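

Among the compounds shown here, on the core of compound 3, the change from 4-bromophenyl to 4-iodophenyl gives in this assay a 2.5-fold lower number from compound 3 to compound 4 (0.40 log units; beyond the scatter), a modest step and the only one of this change that can be read here. On the core of compound 1, the same change cannot be read, because compound 1 and compound 2 both give only a limit of the assay, which leaves its size and direction on that core unknown: the limit of > 50000 nM in this assay, at which 2 of the 4 values shown sit. The series therefore shows that iodo in place of bromo on an aromatic carbon can lower the number on one core, but it does not show that this step carries over to the other core, since a single readable step can neither confirm nor contradict such a transfer.

The compounds shown leave open how the read-out would respond to other groups at the same place on the ring, such as chloro, fluoro, an amine or a carboxylic acid, and whether any such step would follow the one seen with iodo. They also leave open how the two cores compare on their own, as each pair across the cores differs in more than one place.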